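This account rests on a few compounds, and the source may have more. Where it says the series, first, only, none or still open, it means among the compounds named here.

Compound 1 `COc1ccc(Nc2nccc(-c3cccnc3)n2)cc1` gives 1700 nM in a functional assay for inhibition, with Homo sapiens as the target; on this read-out lower numbers stand for stronger inhibition and higher numbers for weaker inhibition. Compound 2 `COc1ccc(Nc2nccc(-c3ccncc3)n2)cc1` carries pyridin-4-yl in place of pyridin-3-yl on an aromatic carbon and gives 4200 nM, a 2.5-fold higher number from compound 1 to compound 2 (0.39 log units; beyond the scatter), so compound 2 holds the higher of the two plain numbers. Compound 3 `COc1ccc(N(C)c2nccc(-c3ccncc3)n2)cc1` has methyl in place of hydrogen on a nitrogen on an aromatic ring, and in this assay compound 3 reaches only a limit, > 24000 nM. Compound 4 `Cc1cn(-c2ccc(Nc3nccc(-c4ccncc4)n3)cc2)cn1` differs from compound 2 by 4-methyl-1H-imidazol-1-yl in place of methoxy on an aromatic carbon. Neither measured step alters the methoxy, so neither gives a direct guide; both moved the number upward, yet a change at this place need not follow. For compound 4 the estimate is 3000 nM, within 600 nM to 15000 nM, an expected 1.4-fold lower number from compound 2 to compound 4 (0.15 log units; within the scatter).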

Compound 4, half-maximal inhibitory concentration: > 3000 nM
Compound 4: only a limit was reported; the forecaster's own chance of this, stated with the estimate: 10%; the middle value lies on the limit itself.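

Compound 4 gives > 3000 nM, which is a limit and not a number, so the step from compound 2 to compound 4 cannot be read. From the compounds shown here alone, whether 4-methyl-1H-imidazol-1-yl gives stronger or weaker inhibition than methoxy stays open.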